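A few compounds are considered here, and "the series" means these few. Any claim that something is new, unique, unknown or untested is made for them only; others in the source may bear on it.

Three compounds share one core and differ only in the saturated ring attached to it. Compound 1 `O=C(NO)c1ccc(-c2nc(N3CCCC3)c3ccccc3n2)cc1` gives 57.2% in an assay on isolated protein for inhibition of protein deacetylase HDAC6 (Homo sapiens), tested at 0.5 uM (a lower number here means less inhibition, a higher number more inhibition at the concentration tested (going by the name of the read-out)), compound 2 `CN1CCN(c2nc(-c3ccc(C(=O)NO)cc3)nc3ccccc23)CC1` gives 89.4%, and compound 3 `COc1cc(OC)c2c(N3CCCC3)nc(-c3ccc(C(=O)NO)cc3)nc2c1` gives 55.3%. Compound 3 thus has the lowest of the three numbers; its value and that of compound 1 sit within the usual scatter of each other, while compound 2 lies well above both.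

The step to compound 4 `COc1cc(OC)c2c(N3CCC(F)(F)CC3)nc(-c3ccc(C(=O)NO)cc3)nc2c1` changes compound 3 in one place: 4,4-difluoropiperidin-1-yl in place of pyrrolidin-1-yl on an aromatic carbon.

Going by the values given here, only one measured step bears on this change. It exchanged the same pyrrolidin-1-yl for another six-membered ring, 4-methylpiperazin-1-yl, and gave a number 32.2 percentage points higher from compound 1 to compound 2 (beyond the scatter). The group entering here, 4,4-difluoropiperidin-1-yl, shares the ring size but not the rest of that group, and the two measured compounds carrying dimethoxy groups (compound 3 alone) give no further guidance. A rise is therefore plausible but far from certain, and its size may well fall short of the earlier step.

For compound 4 the expected result in this assay is 65%, with a likely range from 45% to 85%, which would mean an expected step of a number 9.7 percentage points higher from compound 3 to compound 4 (within the scatter).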

Compound 4, a percentage reported as inhibition, at one concentration (the size of the read-out at that concentration, not a potency): 53.2%
The estimate for compound 4 lay 11.8 percentage points above the measured number, and the stated range covers the measured number.
By their numbers in this assay, from the lowest: compounds 4, 3 and 1 (each within the scatter of the next); then compound 2.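

In this assay, placing 4,4-difluoropiperidin-1-yl on this aromatic carbon instead of pyrrolidin-1-yl gives a number 2.1 percentage points lower from compound 3 to compound 4 (within the scatter), so on the core of compound 3 this exchange leaves the number unchanged within the usual scatter. A move from the five-membered to a six-membered non-aromatic ring therefore does not bring a rise by itself, at least with this ring on this core, whereas the earlier exchange for 4-methylpiperazin-1-yl on the core of compound 1 gave a number 32.2 percentage points higher from compound 1 to compound 2 (beyond the scatter). Nothing measured here explains why these two exchanges turn out so differently.

The two steps differ both in the entering ring and in the dimethoxy groups on the core, so the compounds shown cannot separate the contribution of one from the other; 4-methylpiperazin-1-yl on the core of compound 3 would settle that point directly. Plain piperidin-1-yl or morpholin-4-yl at the same place would further show whether the large rise needs the methyl-bearing ring nitrogen or whether the two fluorine atoms are cancelling a gain from the larger ring.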